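Hydrazide series: from compound 3 toward compound 4

The source may hold more compounds than are shown below. What is called first, only, known or untested is meant among the compounds shown, and "the series" means these compounds.

Measured so far in a functional assay on CCRF-CEM cells (Homo sapiens) for inhibition, read by MTT assay, with a stated time of 4 days; a higher number here means a weaker inhibitor, a lower number a stronger inhibitor:
compound 1 `CCOC(=O)NC(c1ccccc1)c1ccc(Cl)cc1` — a limit, > 250000 nM
compound 2 `COc1cc(NC(C)CCCNC(=O)NNC(=O)NCCCC(C)Nc2cc(OC)cc3cccnc23)c2ncccc2c1` — 87000 nM
compound 3 `COc1cc(NC(C)CCCNC(=O)NN)c2ncccc2c1` — a limit, > 250000 nM

Compound 3 sits at the limit of > 250000 nM in this assay, at which 2 of the 3 values shown sit, so its value is a limit and not a number. Compound 2 gives a measured value in this assay, while compound 1 gives only a limit there. Compound 4 `COc1cc(NC(C)CCCNC(=O)NNC(=O)NCCO)c2ncccc2c1` is not yet measured; it differs from compound 3 by (2-hydroxyethyl)carbamoyl in place of hydrogen on an amine nitrogen. For the measured compounds named here, no measured pair shows this change, so the step is expected to stay within the scatter or move only modestly toward inhibition. Compound 4 is therefore expected at 200000 nM, from 60000 nM to 700000 nM, with a step of an at least 1.2-fold lower number from compound 3 to compound 4 (0.09 log units; that floor lies within the scatter) estimated from compound 3.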

Compound 4, half-maximal inhibitory concentration: > 250000 nM
Compound 4: a limit, no number (the forecaster's own chance of this, stated with the estimate: 60%); middle value at least 1.2-fold (0.09 log units) away from the limit.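

Compound 3 and compound 4 both stand only as limits in this assay, so no step between them can be read: the limit of > 250000 nM in this assay, at which 3 of the 4 values shown sit.

Going by these compounds, whether (2-hydroxyethyl)carbamoyl in place of hydrogen on an amine nitrogen shifts inhibition at all remains open.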